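The source may hold more compounds than are shown below. What is called first, only, known or untested is meant among the compounds shown, and "the series" means these compounds.

Measured compounds:
compound 1, `CC(C)NS(=O)(=O)Cc1noc2ccccc12` — 56 mg/kg
compound 2, `NS(=O)(=O)Cc1noc2ccc(F)cc12` — 15 mg/kg

Of the compounds shown here, two have been measured in a functional assay on the whole organism (strain STD-dd) with Mus musculus as the target, in the maximal electroshock model, with a stated time of 2 h; a lower number here means that less compound is needed, a higher number that more compound is needed for the effect. Compound 1 carries an isopropyl group on the sulfonamide nitrogen and no fluoro on the core; in this assay compound 1 gives 56 mg/kg. Compound 2 has a primary sulfonamide and a fluoro on the core, and in this assay compound 2 gives 15 mg/kg. Of the two numbers, compound 2 has the lower one; the number for compound 1 is higher, and the gap between them is beyond the usual scatter. Among the compounds with values here, the two compounds differ in two places, so no single step can be drawn between them.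

Compound 3, `CN(C)S(=O)(=O)Cc1noc2ccc(F)cc12`, has not yet been measured. Relative to compound 2 the change is dimethylamino in place of amino on a sulfonyl sulfur. With only compound 1 and compound 2 as guides, a step toward a higher number is expected, of moderate size: the estimated step is a 2.7-fold higher number from compound 2 to compound 3 (0.43 log units; beyond the scatter). The expected value for compound 3 in this assay is 40 mg/kg, with a range from 15 mg/kg to 110 mg/kg.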

Compound 3, dose for half-maximal effect: 32 mg/kg
Beside the measured number, compound 3's estimate is 1.3-fold (0.10 log units) above it; the range from low to high includes it.
By their numbers in this assay, from the lowest: compound 2; then compounds 3 and 1 (each within the scatter of the next).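

Within the data shown here, compound 2 and compound 3 differ in one place only, so this is the first single change that can be read in this assay: dimethylamino in place of amino on a sulfonyl sulfur gives a 2.1-fold higher number from compound 2 to compound 3 (0.33 log units; beyond the scatter) and is a modest step. Dimethylamino carries no hydrogen-bond donor, yet compound 3 still reaches the half-maximal effect at 32 mg/kg in this assay, so a hydrogen on this nitrogen is not required for a measurable effect in this series. The data shown offer no measurement that explains the step.

On these data alone, whether a single methyl on this nitrogen would give a number closer to that of compound 2 or compound 3 remains open, as does whether a ring amine such as morpholine or pyrrolidine on the same sulfur would continue in the same direction. The separate contribution of the fluoro on the core and that of the isopropyl group on the nitrogen also cannot be read, as no pair shown differs in either alone.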